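Bromo in Place of Trifluoromethyl on Compound 3

The source may report more compounds than this note shows. Statements on the series, on what has been measured and on what is new or still open speak of the compounds shown alone.

Of the compounds shown here, three have been tested in an assay for inhibition of Tryptophan 2,3-dioxygenase (Homo sapiens), with stated times of 10 min and 60 min, tested at 10 uM; a lower number here means a weaker effect, a higher number a stronger effect of the compound at the concentration tested. Compound 1, `O=C1NCc2c(NCc3ccccc3[N+](=O)[O-])cccc21`, gives 23%. Compound 2, `N#Cc1cc(NCc2ccccc2[N+](=O)[O-])c2cn[nH]c2c1`, gives 22%. Compound 3, `FC(F)(F)c1cccc(CNc2cc(C(F)(F)F)cc3[nH]ncc23)c1`, gives 40%, which is the highest of the three numbers; its distance from compound 1 and from compound 2 is in each case beyond the usual scatter of this assay , so compound 3 stands as the strongest of the three measured compounds.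

Compound 4, `FC(F)(F)c1cc(NCc2cccc(Br)c2)c2cn[nH]c2c1`, has not yet been measured. It differs from compound 3 in one place: bromo in place of trifluoromethyl on an aromatic carbon. The two compounds share everything else, including the trifluoromethyl that sits on the shared core.

Among the measured compounds shown here, no pair of the measured compounds differs in a single place, so there is no measured step to lean on for this change. The exchange is small in atom count, and compound 3 already provides the highest value with 40%. The step from compound 3 to compound 4 is expected to be modest, most likely none beyond the scatter, with a slight downward lean, amounting to a number 5 percentage points lower from compound 3 to compound 4 (within the scatter). Compound 4 is therefore estimated to give 35% in this assay , with a range from 18% to 52%.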

Compound 4, a percentage reported as inhibition, at one concentration (the size of the read-out at that concentration, not a potency): 67%
For compound 4 the middle estimate is 32 percentage points below the measured one; measured number above the stated range.
By their numbers in this assay, from the lowest: compounds 2 and 1 (each within the scatter of the next); then compound 3; then compound 4.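

In this assay, among the compounds shown here, putting bromo in place of trifluoromethyl on an aromatic carbon, meta to a large group, gives a number 27 percentage points higher from compound 3 to compound 4 (beyond the scatter), and this is the only step in the set that isolates a single change. It shows that this position is sensitive to what it carries: the read-out moves even though four heavy atoms leave, one enters, and neither group brings a ring, a hydrogen-bond donor or acceptor, or a net charge. The rise shows only that the read-out responds to this exchange, and no measurement offered here accounts for it.

The compounds shown leave open whether the gain is particular to bromo or would also appear with chloro, methoxy or an amine on the same aromatic carbon, and a single step cannot show how far the trend extends. They also leave open whether the trifluoromethyl on the shared core, which stays in place through this step, would respond in the same way to bromo, or whether the same exchange would hold on a different core.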